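One more methoxy on the nitro-bearing ring

A few compounds are considered here, and "the series" means these few. Any claim that something is new, unique, unknown or untested is made for them only; others in the source may bear on it.

Measured in a functional assay on MDA-MB-231 cells (Homo sapiens) for antiproliferative activity, read by sulforhodamine B assay, with a stated time of 48 h; on this read-out lower numbers stand for stronger inhibition and higher numbers for weaker inhibition:
- compound 1 `COc1cc(C(=O)/C=C\Nc2ccc(-c3nc4cc(OC)c(OC)c(OC)c4s3)cc2C)cc([N+](=O)[O-])c1OC`: 12800 nM
- compound 2 `COc1cc(OC)c2sc(-c3ccc(N/C=C\C(=O)c4ccc(OC)c([N+](=O)[O-])c4)cc3)nc2c1`: 12900 nM
- compound 3 `COc1ccc(C(=O)/C=C\Nc2ccc(-c3nc4cc(OC)c(OC)c(OC)c4s3)cc2)cc1[N+](=O)[O-]`: 17100 nM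

These three values lie within the usual scatter of repeated measurements, so no order can be read among them. Compound 3 therefore stands level with compound 1 and compound 2 in this assay.

The next compound is compound 4 `COc1cc(C(=O)/C=C\Nc2ccc(-c3nc4cc(OC)c(OC)c(OC)c4s3)cc2)cc([N+](=O)[O-])c1OC`. It keeps everything in compound 3 and puts a methoxy in place of hydrogen on an aromatic carbon. The new group sits ortho to a methoxy group and meta to a nitro group.

Two pieces of evidence bear on this change. The same kind of swap, made elsewhere in the molecule, gave a 1.3-fold higher number from compound 2 to compound 3 (0.12 log units; within the scatter), so it was a small step. Compound 1 already carries the extra methoxy, along with a methyl group that compound 4 lacks, and compound 1 gives 12800 nM. Neither points to a real shift, so no step beyond the scatter is expected in this assay, in either direction.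

The expected change is a 1.2-fold lower number from compound 3 to compound 4 (0.09 log units; within the scatter). For compound 4 the estimated value is 14000 nM, with an expected range from 6500 nM to 30000 nM.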

Compound 4, half-maximal inhibitory concentration: 9800 nM
Estimate against measurement, compound 4: 1.4-fold (0.15 log units) above; measured number inside the range.
By their numbers in this assay, from the lowest: compounds 4, 1, 2 and 3 (each within the scatter of the next).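

In this assay the step of a 1.7-fold lower number from compound 3 to compound 4 (0.24 log units; within the scatter) shows that a methoxy ortho to a methoxy group and meta to a nitro group can take the place of hydrogen on this ring without a shift that stands out from the scatter. The step of a 1.3-fold lower number from compound 1 to compound 4 (0.12 log units; within the scatter) adds that hydrogen in place of methyl on the other aromatic ring also stays within the scatter, so with the extra methoxy present, neither the methyl nor its absence gives a readable change. Nothing measured here offers a reason for why these steps are so small.

Among the compounds shown this position holds only hydrogen or methoxy, so it remains open whether an amine, a hydroxyl or a carboxylic acid there would move the number beyond the scatter. As far as these compounds go, all four compounds also keep the nitro group, so how much the number depends on that group, and whether a nitrile or a simple hydrogen could stand in its place, also remains open.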